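Hydroxy added to the nitrobenzyl ring of compound 2

This account rests on a few compounds, and the source may have more. Where it says the series, first, only, none or still open, it means among the compounds named here.

Compound 1, `COC(=O)c1cc(NCc2ccccc2[N+](=O)[O-])c2cn[nH]c2c1`: 16%
Compound 2, `O=[N+]([O-])c1ccccc1CNc1cc(Br)cc2[nH]ncc12`: 52%

In an assay for inhibition of Tryptophan 2,3-dioxygenase (Homo sapiens), with stated times of 10 min and 60 min, tested at 10 uM (a lower number here means a weaker effect, a higher number a stronger effect of the compound at the concentration tested), compound 2 gives 52%, the higher of the two numbers; compound 1 gives 16%. Going by the values given here, the one measured step, a number 36 percentage points higher from compound 1 to compound 2 (beyond the scatter), changes the core and not the nitro-bearing ring, so no measured step bears on the change to compound 3, `O=[N+]([O-])c1ccc(O)cc1CNc1cc(Br)cc2[nH]ncc12`: hydroxy in place of hydrogen on an aromatic carbon. Compound 3 is therefore expected to stay near compound 2, the step of a number 2 percentage points lower from compound 2 to compound 3 (within the scatter) estimated within the scatter. Compound 3 is estimated at 50%, within 25% to 75%.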

Compound 3, a percentage reported as inhibition, at one concentration (the size of the read-out at that concentration, not a potency): 96%
Compound 3: the middle estimate sits 46 percentage points below what was measured; measured number above the stated range.
By their numbers in this assay, from the lowest: compound 1; then compound 2; then compound 3.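

In this assay, hydroxy in place of hydrogen, para to a nitro group, brings a number 44 percentage points higher from compound 2 to compound 3 (beyond the scatter) and so shows that this ring carbon, which the earlier step left unchanged, strongly affects the read-out with the core held constant. A single added oxygen is enough for this large change. No supporting data explain the rise.
From the compounds shown here alone, whether hydroxy itself is required remains open, as methoxy or an amine at this carbon would test that. Going by these compounds, compound 3 is also read at one concentration only, so its effect at any other concentration remains open.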